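A few compounds are considered here, and "the series" means these few. Any claim that something is new, unique, unknown or untested is made for them only; others in the source may bear on it.

Measured so far:
compound 1, `COc1ccc2[nH]c(C(=O)N3CC(=O)N(Cc4ccccc4)[C@@H](CN4CCC(C)CC4)C3)cc2c1`: 93100 nM
compound 2, `Cc1ccc2[nH]c(C(=O)N3CC(=O)N(Cc4ccccc4)[C@@H](CN4CCC5(CCC5)CC4)C3)cc2c1`: 12300 nM

In a physicochemical assay for solubility, read by spectrophotometry, in phosphate buffer, with a stated time of 2 h, at pH 7.4 (a higher number here means a more soluble compound, a lower number a less soluble compound), compound 1 gives 93100 nM, the higher of the two numbers in hand, and compound 2 gives 12300 nM, a gap beyond the scatter. For the measured compounds named here, the two differ in more than one place, so no single step is drawn between them.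

Compound 3, `COc1ccc2[nH]c(C(=O)N3CC(=O)N(Cc4ccccc4)[C@@H](CN4C(=O)c5ccccc5C4=O)C3)cc2c1`, is not yet measured. It follows from compound 1 by one change: a group of 11 heavy atoms (8 carbon, 1 nitrogen, 2 oxygen; one five-membered non-aromatic ring with 1 hetero atom, one six-membered aromatic ring of carbon only) in place of a group of 7 heavy atoms (6 carbon, 1 nitrogen; one six-membered non-aromatic ring with 1 hetero atom), on a saturated chain carbon bound to a saturated ring carbon The 4-methylpiperidin-1-yl group leaves, and the new group, with its five-membered non-aromatic ring and six-membered aromatic ring of carbon only, enters on the saturated chain carbon bound to a saturated ring carbon.

Going by the values given here, no measured step covers a change of this kind, so the expectation rests on the structural change alone. A downward step in this assay is expected, larger than the scatter. The expected step from compound 1 to compound 3 is a 12-fold lower number from compound 1 to compound 3 (1.07 log units; beyond the scatter). Compound 3 is estimated at 8000 nM, within 2000 nM to 30000 nM.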

Compound 3, solubility: > 100000 nM
Compound 3: only a limit was reported; the forecaster's own chance of this, stated with the estimate: 10%; middle value at least 12-fold (1.09 log units) away from the limit.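

In this assay compound 3 gives > 100000 nM, which is a limit of the assay and not a number. Read as a step, this is an at least 1.0-fold higher number from compound 1 to compound 3 (0.03 log units; that floor lies within the scatter), so only the floor of the change is known. On the saturated chain carbon bound to a saturated ring carbon, the larger two-ring group with its two double bonds outside aromatic rings can replace 4-methylpiperidin-1-yl with no fall in the number, and any rise stays hidden at the top of the read-out: the limit of > 100000 nM in this assay, at which 1 of the 3 values shown sits.

Going by these compounds, how far compound 3 truly lies from compound 1 stays open, and so does whether the step exceeds the scatter at all. Also open, on these data alone, is what a morpholine or a carboxylic acid on the same carbon would give in this assay.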